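The source may report more compounds than this note shows. Statements on the series, on what has been measured and on what is new or still open speak of the compounds shown alone.

The measured compounds:
compound 1, `O=C1C(Nc2cccc(Cl)c2)=CC(=O)c2c1nc1n2[C@H]2OC[C@@H](O)[C@H]2OC1`, 7970 nM;
compound 2, `O=C1C(N2CCCCC2)=CC(=O)c2c1nc1n2[C@H]2OC[C@@H](O)[C@H]2OC1`, > 16000 nM;
compound 3, `O=C1C(NC2CCCC2)=CC(=O)c2c1nc1n2[C@H]2OC[C@@H](O)[C@H]2OC1`, > 16000 nM.

Of the compounds shown here, three on a shared core have been tested in a functional assay on HeLa cells (Homo sapiens) for inhibition, read by sulforhodamine B assay; a higher number here means a weaker inhibitor, a lower number a stronger inhibitor. Compound 1, which carries a (3-chlorophenyl)amino group on a double-bonded ring carbon, gives a number in this assay. For compound 2 this assay reports only a limit of the assay, not a number. For compound 3 this assay likewise reports only a limit, so compound 3 stands at the limit and has no number of its own; (the limit of > 16000 nM in this assay, at which 2 of the 3 values shown sit).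

Compound 4, `O=C1C(Nc2ccc(C(F)(F)F)cc2)=CC(=O)c2c1nc1n2[C@H]2OC[C@@H](O)[C@H]2OC1`, differs from compound 3 in one place: 4-(trifluoromethyl)phenyl in place of cyclopentyl on an amine nitrogen. Going by the values given here, two measured steps bear on this change. The step of an at least 2.0-fold higher number from compound 1 to compound 3 (0.30 log units; that floor lies within the scatter) runs from an aryl amine to the cyclopentyl amine and rises to the limit. The step that the two limits leave unreadable from compound 2 to compound 3 cannot be read from its two limits. Reversing the first of these, an aryl amine in place of cyclopentyl is expected to bring compound 4 back from the limit into the measurable region, near where compound 1 sits. Compound 4 is therefore expected to give roughly 9000 nM, between 3000 nM and 16000 nM, a fall of an at least 1.7-fold lower number from compound 3 to compound 4 (0.24 log units; that floor lies within the scatter) that is expected rather than known.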

Compound 4, half-maximal inhibitory concentration: 8920 nM
Estimate against measurement, compound 4: 1.0-fold (0.00 log units) above, within the range that was stated.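

In this assay, on these data alone, 4-(trifluoromethyl)phenyl in place of cyclopentyl on the amine nitrogen gives an at least 1.7-fold lower number from compound 3 to compound 4 (0.25 log units; that floor lies within the scatter), so this change yields a readable number, although the size of the step remains open on one side. Exchanging one aryl group for another on the same nitrogen gives a 1.1-fold higher number from compound 1 to compound 4 (0.05 log units; within the scatter), so 3-chlorophenyl and 4-(trifluoromethyl)phenyl are not told apart here, even though they differ in both substituent and printed name. Both compounds with a number, compound 1 and compound 4, now carry an aryl group on the amine nitrogen, while compound 2 and compound 3, which carry none, each stand at a limit of the assay: the limit of > 16000 nM in this assay, at which 2 of the 4 values shown sit.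

The compounds shown leave open whether an unsubstituted phenyl, a phenyl bearing a methoxy group or a carboxylic acid, or a benzyl group on the same nitrogen would give a number in this range in this assay. They also leave open how far compound 2 and compound 3 really lie from the aryl amines, since only limits stand for those two.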